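The compounds below may be only part of what the source reports. "The series", "measured", "known", "first", "only" and "open" are said of these compounds alone.

Compound 1 `COc1ccc(C2Cc3ccccc3C(C3=C(O)OCCC3=O)C2)cc1` in a functional assay on HCT-15 cells (Homo sapiens) for inhibition, with a stated time of 72 h (a lower number here means a stronger inhibitor, a higher number a weaker inhibitor), gives > 10000 nM, which is a limit of the assay and not a number.
Compound 2 `CC1(c2ccccc2)CC(=O)C(C2CC(c3ccc(-c4ccc(Br)cc4)cc3)Cc3ccccc32)=C(O)O1` in this assay gives 1310 nM.

Compound 2 stands on the only number shown; the one other value is a limit (the limit of > 10000 nM in this assay, at which 1 of the 2 values shown sits), so no step between measured compounds can be described. Compound 3 `COc1ccc(C2Cc3ccccc3C(C3=C(O)OC(C)(c4ccccc4)CC3=O)C2)cc1` has not yet been measured. It is made from compound 2 by one change, (methoxy in place of 4-bromophenyl on an aromatic carbon). The same methoxy group also sits on compound 1, whose result in this assay was only a limit, while the core of compound 1 lacks the methyl and phenyl groups found on the second ring of compound 2 and compound 3. That comparison is not a single step, so it can only hint. Given that compound 1 with a methoxy reached no number in this assay, compound 3 is expected to be a weaker inhibitor than compound 2, with the estimated step from compound 2 to compound 3 being a 4.6-fold higher number from compound 2 to compound 3 (0.66 log units; beyond the scatter), beyond the usual scatter. For compound 3 the estimated value in this assay is 6000 nM, expected to lie between 2000 nM and 20000 nM.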

Compound 3, half-maximal inhibitory concentration: > 10000 nM
Compound 3: only a limit was reported; the forecaster's own chance of this, stated with the estimate: 40%; at least 1.6-fold (0.22 log units) between middle value and limit.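

In this assay, putting methoxy in place of 4-bromophenyl on this aromatic carbon, para to a large group, gives an at least 7.6-fold higher number from compound 2 to compound 3 (0.88 log units; beyond the scatter). Going by these compounds alone, this is the first comparison here that turns on a single change: the rest of the molecule, including the methyl and phenyl groups on the second ring, stays the same, so the loss of measurable inhibition can be tied to this position and not to the differences in the core of compound 1. The result for compound 3 is a limit of the assay and not a number, so the step has a known lower end but no known upper end: the limit of > 10000 nM in this assay, at which 2 of the 3 values shown sit.

The compounds shown leave open whether the bromine or the outer aromatic ring matters more, as the two leave together in this change. They also do not show how a plain phenyl, with no bromine, or a group of another kind such as an amine or a longer carbon chain, would read at this position.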